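Bromo in Place of Methoxy on Compound 1

This account rests on a few compounds, and the source may have more. Where it says the series, first, only, none or still open, it means among the compounds named here.

Compound 1 `COc1ccc(/C(Cl)=C/C=C(\C#N)C(=O)c2c(C)[nH]c3ccccc23)cc1` reaches the limit of a functional assay on MCF7 cells (Homo sapiens) for cytotoxicity, read by sulforhodamine B assay, with a stated time of 48 h (a higher number here means a weaker inhibitor of growth, a lower number a stronger inhibitor of growth), where compound 1 gives > 100000 nM, a limit rather than a number. Its near relative compound 2 `COc1ccc(/C(Cl)=C/C=C(\C#N)C(=O)c2c(C)[nH]c3ccccc23)cc1OC` gives 93000 nM in this assay, and the step of an at least 1.0-fold lower number from compound 1 to compound 2 (0.03 log units; that floor lies within the scatter) stays within the scatter. Compound 3 `Cc1[nH]c2ccccc2c1C(=O)/C(C#N)=C/C=C(\Cl)c1ccc(Br)cc1` carries bromo in place of methoxy on an aromatic carbon. For the measured compounds named here, no measured step covers a bromo group; the single step on record, methoxy in place of hydrogen, moved nothing beyond the scatter, so the expected step of a number no higher from compound 1 to compound 3 (the limit leaves the size open) is likewise none beyond the scatter. Compound 3 is estimated at 100000 nM, within 30000 nM to 300000 nM.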

Compound 3, concentration for total growth inhibition: 73800 nM
Compound 3: the middle estimate sits 1.4-fold (0.13 log units) above what was measured; measured number inside the range.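

For the compounds shown here, the step, an at least 1.3-fold lower number from compound 1 to compound 3 (0.13 log units; that floor lies within the scatter), is the first on record that takes the methoxy away from this place, on an aromatic carbon para to a large group, and puts bromo there. With bromo in this place, this assay gives a measured number, but the floor of the step shows no change beyond the scatter. The real size of the step stays open, because compound 1 is a limit: the limit of > 100000 nM in this assay, at which 1 of the 3 values shown sits.

The compounds shown leave open what an amine or a carboxylic acid would give in this place. They also leave open whether any change to the shared core would move the number.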